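Swapping hydroxy for (ethylcarbamoyl)amino on the shared core

The source may hold more compounds than are shown below. What is called first, only, known or untested is meant among the compounds shown, and "the series" means these compounds.

In a functional assay on HeLa cells (Homo sapiens) for cytotoxicity (a higher number here means a weaker inhibitor, a lower number a stronger inhibitor), compound 1 `O=C(Nc1ccccc1)Nc1[nH]nc2nnc(-c3ccccc3)c(-c3ccccc3)c12` gives 2930 nM. Compound 2 `Oc1[nH]nc2nnc(-c3ccccc3)c(-c3ccccc3)c12` reads > 100000 nM, which is a limit of the assay and not a number. Compound 3 `CCNC(=O)Nc1[nH]nc2nnc(-c3ccccc3)c(-c3ccccc3)c12` has not yet been measured. It keeps the core of compound 2 and differs in one place, with (ethylcarbamoyl)amino in place of hydroxy on an aromatic carbon. Among the compounds with values here, one measured step bears on this change, an at least 34-fold higher number from compound 1 to compound 2 (1.53 log units; beyond the scatter), which is large and beyond the scatter. There, hydroxy took the place of (phenylcarbamoyl)amino. Compound 3 brings back a closely related group, with ethyl where compound 1 has phenyl, so a large move to a lower number is expected in this assay, towards the 2930 nM of compound 1. Within the data shown here, no measured step shows what the change from phenyl to ethyl does, so the range stays wide. The expected step is an at least 16-fold lower number from compound 2 to compound 3 (1.22 log units; beyond the scatter). Compound 3 is estimated at 6000 nM, with an expected range from 1500 nM to 40000 nM.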

Compound 3, half-maximal inhibitory concentration: 60400 nM
The estimate for compound 3 lay 10-fold (1.00 log units) below the measured number; measured number outside the range, above it.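

In this assay, the step of a 21-fold higher number from compound 1 to compound 3 (1.31 log units; beyond the scatter) shows that the group at the end of this side chain counts: keeping the amide-type nitrogen and carbonyl while putting ethyl in place of phenyl does not hold the number of compound 1. The second step, an at least 1.6-fold lower number from compound 2 to compound 3 (0.21 log units; that floor lies within the scatter), is only a floor, and that floor lies within the scatter, so it shows no clear gain from (ethylcarbamoyl)amino over hydroxy. The value of compound 2 is a limit of the assay and not a number, which is why this step has no upper size: the limit of > 100000 nM in this assay, at which 1 of the 3 values shown sits.

As far as these compounds go, whether a ring on that nitrogen is what matters stays open, and a cyclohexyl group or a longer chain such as butyl there would test it. A plain amine on the same aromatic carbon would show what the side chain adds beyond that nitrogen.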